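The compounds below may be only part of what the source reports. "The series", "measured", "known", "first", "only" and "open" are said of these compounds alone.

Of the compounds shown here, three that share one core have been tested in a functional assay on CCRF-CEM cells (Homo sapiens) for antiproliferative activity, with a stated time of 72 h; on this read-out lower numbers stand for stronger inhibition and higher numbers for weaker inhibition. Compound 1 `OC[C@H]1O[C@@H](n2cnc3c(NCc4ccc(Cl)cc4)ncnc32)[C@H](O)[C@@H]1O` gives 10200 nM in this assay. Compound 2 `COc1cccc(CNc2ncnc3c2ncn3[C@@H]2O[C@H](CO)[C@@H](O)[C@H]2O)c1` gives 7600 nM. Compound 3 `COc1ccc(CNc2ncnc3c2ncn3C2OC(CO)[C@@H](O)[C@H]2O)c(O)c1` gives 12800 nM. Of these three numbers, that of compound 2 is the lowest, yet its gap to compound 1 and its gap to compound 3 both stay within the usual scatter of repeated measurements, so the three cannot be placed in any firm order. Within the data shown here, the one step between compounds that differ in a single place is a 1.3-fold lower number from compound 1 to compound 2 (0.13 log units; within the scatter), a change that lies within the scatter.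

Compound 4 `Cc1cccc(CNc2ncnc3c2ncn3[C@@H]2O[C@H](CO)[C@@H](O)[C@H]2O)c1O` has not yet been measured. It differs from compound 2 in one place: 2-hydroxy-3-methylphenyl in place of 3-methoxyphenyl on a saturated chain carbon bound to a nitrogen on an aromatic ring. Among the measured compounds shown here, only the step from compound 1 to compound 2 bears directly on this change, since it also exchanges the group on that same chain carbon, and it produced no movement beyond the scatter. Compound 3 likewise gives a number within the scatter of compound 2. Nothing here points to a shift beyond the scatter, so the estimate for compound 4 in this assay is 9000 nM, with a range of 4000 nM to 20000 nM. For compound 4 the expected step is therefore a 1.2-fold higher number from compound 2 to compound 4 (0.07 log units; within the scatter).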

Compound 4, half-maximal inhibitory concentration: 900 nM
Compound 4: the middle estimate sits 10-fold (1.00 log units) above what was measured, outside the stated range (below it).
By their numbers in this assay, from the lowest: compound 4; then compounds 2, 1 and 3 (each within the scatter of the next).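

In this assay the group on this saturated chain carbon proves able to move the number well beyond the scatter: 2-hydroxy-3-methylphenyl in place of 3-methoxyphenyl gives an 8.4-fold lower number from compound 2 to compound 4 (0.93 log units; beyond the scatter) and, set against the 4-chlorophenyl group, it gives an 11-fold lower number from compound 1 to compound 4 (1.05 log units; beyond the scatter). The earlier exchange at the same place, a 1.3-fold lower number from compound 1 to compound 2 (0.13 log units; within the scatter), had suggested that this position made little difference, so that impression does not hold for all groups placed there. The leaving and entering groups have the same atoms, joined differently, and the entering group counts one hydrogen-bond donor where the leaving group counts none, yet no measurement here explains the drop in the number.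

The compounds shown hold no ring carrying only the hydroxy or only the methyl of 2-hydroxy-3-methylphenyl, so it remains open which of the two carries the step, or whether it takes both. Also open, going by these compounds, is whether an amine or a carboxylic acid standing in for that hydroxy would keep the lower number.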